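Chloro to Bromo on the Hydroxyphenyl Ring: Expecting Compound 4

The source may hold more compounds than are shown below. What is called first, only, known or untested is meant among the compounds shown, and "the series" means these compounds.

Measured compounds:
Compound 1, `O=C(CSc1nnc(-c2ccncc2)o1)N/N=C/c1ccc(Cl)cc1`, gives 15300 nM in a functional assay on MCF7 cells (Homo sapiens) for cytotoxicity, read by MTT assay, with a stated time of 48 h; on this read-out lower numbers stand for stronger inhibition and higher numbers for weaker inhibition.
Compound 2, `O=C(CSc1nnc(-c2ccncc2)o1)N/N=C/c1ccc(Br)cc1`, gives 19100 nM in this assay.
Compound 3, `O=C(CSc1nnc(-c2ccncc2)o1)N/N=C/c1cc(Cl)ccc1O`, gives 5830 nM in this assay.

The three measured compounds share one core and differ only in the aromatic ring attached to the carbon with a double bond to nitrogen. Compound 1 and compound 2 differ by a single atom: bromo in place of chloro on an aromatic carbon. That exchange gave a 1.2-fold higher number from compound 1 to compound 2 (0.10 log units; within the scatter), so the two numbers cannot be ranked against each other. Compound 3 carries a different ring, the change being (5-chloro-2-hydroxyphenyl in place of 4-chlorophenyl on a carbon with a double bond to nitrogen), and this gave a 2.6-fold lower number from compound 1 to compound 3 (0.42 log units; beyond the scatter); the related comparison gave a 3.3-fold lower number from compound 2 to compound 3 (0.52 log units; beyond the scatter). Compound 3 therefore stands with the lowest number of the three.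

Compound 4, `O=C(CSc1nnc(-c2ccncc2)o1)N/N=C/c1cc(Br)ccc1O`, has not yet been measured in this assay. It differs from compound 3 as bromo in place of chloro on an aromatic carbon. Within the data shown here, this is the same kind of change as the one between compound 1 and compound 2, not the same change: there the halogen sits para to a large group, whereas here it sits meta to a large group and para to a hydroxy group. Among the measured compounds shown here, compound 4 is expected to show a 1.2-fold higher number from compound 3 to compound 4 (0.07 log units; within the scatter), because the one earlier step of this kind was a 1.2-fold higher number from compound 1 to compound 2 (0.10 log units; within the scatter). For the measured compounds named here, with only one prior example, this expectation is loosely held. Compound 4 is thus estimated at about 6800 nM, likely between 3500 nM and 13500 nM.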

Compound 4, half-maximal inhibitory concentration: 7770 nM
Compound 4: the middle estimate sits 1.1-fold (0.06 log units) below what was measured, and the stated range covers the measured number.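

Exchanging chloro for bromo on the hydroxyphenyl ring in this assay gave a 1.3-fold higher number from compound 3 to compound 4 (0.12 log units; within the scatter), and the same exchange on the ring without a hydroxy group gave a matching result: the same change on two cores in this assay, a 1.2-fold higher number (0.10 log units; within the scatter) from compound 1 to compound 2 and a 1.3-fold higher number (0.12 log units; within the scatter) from compound 3 to compound 4, 1.1-fold (0.03 log units) apart, within the scatter of two such steps

So in these two pairs the exchange carries over from one core to the other, leaving the number within the usual scatter each time, but two pairs cannot show that this holds on other cores, and neither pair separates bromo from chloro. Among these compounds, the bromo pair and the mixed pair also read differently for the ring change itself, with a 2.5-fold lower number from compound 2 to compound 4 (0.39 log units; beyond the scatter) lying beyond the scatter and a 2.0-fold lower number from compound 1 to compound 4 (0.29 log units; within the scatter) lying within it, so the step to compound 4 from a ring without a hydroxy group is firm in only one of the two comparisons.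

The compounds shown leave open whether fluoro, iodo or methyl in the place of the halogen would also keep the number within the scatter. They also leave open what a methoxy group or an amine would do in the place of the hydroxy group.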